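A few compounds are considered here, and "the series" means these few. Any claim that something is new, unique, unknown or untested is made for them only; others in the source may bear on it.

Compound 1 `N#Cc1cnc(NCc2cnccc2C(F)(F)F)cc1NC[C@H]1C[C@H](O)C1` gives > 10000 nM in an assay on isolated protein for inhibition of protein kinase C delta type (Homo sapiens), read by TR-FRET, with a stated time of 2 h (a lower number here means a stronger inhibitor, a higher number a weaker inhibitor), a limit of the assay rather than a number. Compound 2 `N#Cc1cnc(NCc2ccccc2C(F)(F)F)cc1N[C@H]1CC[C@@H](O)CC1` gives 4500 nM in this assay. Compound 3 `N#Cc1cnc(NCc2ccccc2C(F)(F)F)cc1N[C@H]1CC[C@H](O)CC1` gives > 10000 nM in this assay, again a limit.

Compound 1 therefore stands at the weak end of what has been measured, where nothing more than a limit is known. Compound 4 `N#Cc1cnc(NCc2cnccc2C(F)(F)F)cc1NC[C@H]1CC[C@@H](O)CC1` differs from it by 4-hydroxycyclohexyl in place of 3-hydroxycyclobutyl on a saturated chain carbon bound to a nitrogen on an aromatic ring. Going by the values given here, the only measured step, an at least 2.2-fold higher number from compound 2 to compound 3 (0.34 log units; beyond the scatter), concerns configuration alone, because of the fact that compounds 2 and 3 differ only in the configuration as drawn, and says nothing about ring size; no measured step changes a ring in this way. With compound 1 at a limit, only a small change is expected, so compound 4 is estimated at 9000 nM (range 3000 nM to 30000 nM), a step of an at least 1.1-fold lower number from compound 1 to compound 4 (0.04 log units; that floor lies within the scatter).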

Compound 4, half-maximal inhibitory concentration: 500 nM
The estimate for compound 4 lay 18-fold (1.26 log units) above the measured number, and the stated range ends above it.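

On a saturated chain carbon bound to a nitrogen on an aromatic ring, ring size clearly matters: 4-hydroxycyclohexyl in place of 3-hydroxycyclobutyl gives an at least 20-fold lower number from compound 1 to compound 4 (1.30 log units; beyond the scatter) in this assay. The earlier readable step concerned configuration alone, whereas this one changes the ring itself. Compound 1 stands at a limit, > 10000 nM, and the full size of the step is not known. Still open, going by these compounds, is whether the other configuration of the 4-hydroxycyclohexyl ring would keep this strength, and whether an amine in place of the hydroxyl, or a longer chain, would do the same.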